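Swapping cyclohexyl for tert-butyl on a shared core

The compounds below may be only part of what the source reports. "The series", "measured", "known", "first", "only" and "open" are said of these compounds alone.

Measured so far:
- compound 1 `c1cc(C2CCCCC2)ccc1NC1=NCCO1`: 17800 nM
- compound 2 `c1cc(OC2CCCCCC2)ccc1NC1=NCCO1`: 27100 nM
- compound 3 `c1ccc(COc2ccc(NC3=NCCO3)cc2)cc1`: 15900 nM

All three compounds were tested in a functional assay on M21 cells (Homo sapiens) for inhibition, read by sulforhodamine B assay, with a stated time of 48 h; on this read-out higher numbers stand for weaker inhibition of growth and lower numbers for stronger inhibition of growth. Compound 1 stands close to both of the others. Its value of 17800 nM lies within the usual scatter of repeated measurements of the values of compound 2 and compound 3, so this small set shows no real ranking. The three compounds share a core and carry different groups on it, yet their numbers cannot be told apart.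

The next compound is compound 4 `CC(C)(C)c1ccc(NC2=NCCO2)cc1`, which has tert-butyl in place of cyclohexyl on an aromatic carbon. For the measured compounds named here, no two measured compounds differ in one place only, so no measured step can serve as a direct guide to this change. The best available clue is the narrow spread in this assay, from compound 3 at 15900 nM to compound 2 at 27100 nM. On that basis, no change beyond the scatter is expected, although a slight drift towards weaker inhibition of growth would not be surprising. The expected size of the change is a 1.2-fold higher number from compound 1 to compound 4 (0.09 log units; within the scatter). For compound 4 the estimated value is 22000 nM, with an expected range of 11000 nM to 45000 nM.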

Compound 4, concentration for 50% growth inhibition: 2400 nM
Compound 4: the middle estimate sits 9.2-fold (0.96 log units) above what was measured; the measured number lies below the stated range.
By their numbers in this assay, from the lowest: compound 4; then compounds 3, 1 and 2 (each within the scatter of the next).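

In this assay the swap of cyclohexyl for tert-butyl on an aromatic carbon gives a 7.4-fold lower number from compound 1 to compound 4 (0.87 log units; beyond the scatter) and, unlike the differences among compounds 1, 2 and 3, this step lies beyond the scatter, so the group at this position can matter for inhibition of growth. The change itself is narrow: a ring of 6 heavy atoms leaves and an unringed group of 4 heavy atoms enters, all of them carbon, with no hydrogen-bond donors, no hydrogen-bond acceptors and no net charge on either side. Nothing measured here explains why this swap has such an effect.

Going by these compounds, a single step cannot separate the loss of the ring from the drop in heavy atoms, so it remains open whether the branched tert-butyl shape is needed or whether isopropyl or a straight butyl chain would behave the same way. The compounds shown also leave open how a group of a different kind at this position, such as an amine or a carboxylic acid, would compare with tert-butyl.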